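This account rests on a few compounds, and the source may have more. Where it says the series, first, only, none or still open, it means among the compounds named here.

Series notes. Compound 1 `C=CCNc1nc(N)c(C(=O)N=C(N)N)nc1Cl` gives 16% in an assay for inhibition of acid-sensing ion channel 3 (Homo sapiens), read by patch clamp, tested at 1 uM; on this read-out higher numbers stand for more inhibition at the one concentration tested (going by the name of the read-out) and lower numbers for less inhibition. Of the three numbers in hand it stands second highest: compound 3 `NC(N)=NC(=O)c1nc(Cl)c(OCc2ccc3ccccc3c2)nc1N` gives 9%, within the scatter of compound 1, while compound 2 `NC(N)=NC(=O)c1nc(Cl)c(NCc2ccc3ccccc3c2)nc1N` gives 27%, beyond the scatter above compound 1. For the measured compounds named here, no pair of these measured compounds differs in only one place, so no single-point step is available to lean on.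

Compound 4 `NC(N)=NC(=O)c1nc(Cl)c(Sc2ccccc2)nc1N` is not yet measured in this assay. Against compound 1 the change is phenylsulfanyl in place of allylamino on an aromatic carbon. Going by the values given here, with no matched step in the set, the size of the change is uncertain; the expectation is for a step of a number 4 percentage points higher from compound 1 to compound 4 (within the scatter), not beyond the scatter. Compound 4 is estimated at 20%, with a range from 5% to 40%.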

Compound 4, a percentage reported as inhibition, at one concentration (the size of the read-out at that concentration, not a potency): 11%
The estimate for compound 4 lay 9 percentage points above the measured number; the range from low to high includes it.
By their numbers in this assay, from the lowest: compounds 3, 4 and 1 (each within the scatter of the next); then compound 2.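

Phenylsulfanyl in place of allylamino on an aromatic carbon gives a number 5 percentage points lower from compound 1 to compound 4 (within the scatter) in this assay, the first single-place step available at this position. The swap takes out the hydrogen-bond donor of allylamino and brings in a six-membered aromatic ring, yet the step stays within the scatter. Nothing measured bears on the reason for this outcome.

Still open, from the compounds shown here alone, is whether the sulfur link or the phenyl ring matters more, which a phenylamino group at this position could help separate. Going by these compounds, a free amine or a carboxylic acid on a longer chain there also remains untested in these data.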